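This account rests on a few compounds, and the source may have more. Where it says the series, first, only, none or still open, it means among the compounds named here.

Compound 1 `Cc1nc(N2CCC2)nc(OC2CCC2)c1O` gives 96%.
Compound 2 `CCCCCCCCCCCCCCc1nc(N2CCC2)nc(OC2CCC2)c1O` gives 94%.

In a functional assay on cells (Lymphocyte, Homo sapiens), read by a luciferase reporter and ATP content, with a stated time of 48 h, tested at 20 uM (a higher number here means a weaker effect of the compound at the concentration tested, a lower number a stronger effect), compound 2 gives 94%, and compound 1 gives 96%, so the two numbers lie within the scatter of each other and neither compound can be set apart from the other. Compound 3 `CCCCCCCCCCCCCCCCc1nc(N2CCC2)nc(OC2CCC2)c1O` differs from compound 2 by ethyl in place of hydrogen on a saturated chain carbon, ten or more bonds along the chain from an aromatic carbon. For the measured compounds named here, no step between measured compounds of this kind has been seen, and the two measured numbers sit close together, so no step beyond the scatter is expected from compound 2 to compound 3. For compound 3 the estimated step of a number 1 percentage points lower from compound 2 to compound 3 (within the scatter) is small, and its value is expected to be 93%, between 80% and 102%.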

Compound 3, a percentage reported as activity, at one concentration (the size of the read-out at that concentration, not a potency): 103%
The estimate for compound 3 lay 10 percentage points below the measured number; measured number above the stated range.
By their numbers in this assay, from the lowest: compounds 2, 1 and 3 (each within the scatter of the next).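

In this assay ethyl in place of hydrogen on a saturated chain carbon, ten or more bonds along the chain from an aromatic carbon, gives a step (a number 9 percentage points higher from compound 2 to compound 3 (within the scatter)) that stays within the scatter. This change at this place therefore cannot be told apart from no change in the read-out at the concentration tested. Nothing measured here explains the result. The compounds shown leave open whether an amine or a carboxylic acid at the end of the chain would give a step beyond the scatter.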